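A few compounds are considered here, and "the series" means these few. Any claim that something is new, unique, unknown or untested is made for them only; others in the source may bear on it.

In a functional assay on CHO-K1 cells for agonist activity at Glucose-dependent insulinotropic receptor (Homo sapiens), read by a luciferase reporter, with a stated time of 5 h (a higher number here means that more compound is needed for the effect, a lower number that less compound is needed), compound 2 `CC(C)OC(=O)N1CCC(Oc2ncnc3c2CCN3c2ccc(C#N)c(F)c2)CC1` gives 398 nM, the highest of the two numbers measured, and its nearest neighbour compound 1 `CC(C)OC(=O)N1CCC(Oc2ncnc3c2CCN3c2ccc(S(C)(=O)=O)cc2F)CC1` gives 50.1 nM. Among the measured compounds shown here, the one measured step, a 7.9-fold higher number from compound 1 to compound 2 (0.90 log units; beyond the scatter), swapped a 2-fluoro-4-(methylsulfonyl)phenyl for a 4-cyano-3-fluorophenyl. Compound 3 `Cc1cc(S(C)(=O)=O)ccc1N1CCc2c(OC3CCN(C(=O)OC(C)C)CC3)ncnc21` differs from compound 2 by 2-methyl-4-(methylsulfonyl)phenyl in place of 4-cyano-3-fluorophenyl on a nitrogen on an aromatic ring in a ring, which brings back a methylsulfonyl-bearing phenyl. On the strength of a 7.9-fold higher number from compound 1 to compound 2 (0.90 log units; beyond the scatter) the number is expected to fall back most of the way, and a 6.6-fold lower number from compound 2 to compound 3 (0.82 log units; beyond the scatter) is the estimated step. Compound 3 is therefore expected at 60 nM, with a range of 20 nM to 200 nM.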

Compound 3, half-maximal effective concentration: 100 nM
For compound 3 the middle estimate is 1.7-fold (0.22 log units) below the measured one; low and high end bracket the measured number.
By their numbers in this assay, from the lowest: compounds 1 and 3 (each within the scatter of the next); then compound 2.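

The step of a 4.0-fold lower number from compound 2 to compound 3 (0.60 log units; beyond the scatter) shows that, on a nitrogen on an aromatic ring in a ring, a second methylsulfonyl-bearing phenyl also stands apart from the 4-cyano-3-fluorophenyl of compound 2 in this assay. With a 2.0-fold higher number from compound 1 to compound 3 (0.30 log units; within the scatter), methyl in place of fluoro on an aromatic carbon cannot be told from no change here. Nothing available explains either step. Still open, on these data alone, is whether the methylsulfonyl group can give way to a sulfonamide or an acetyl group while the number stays in this range. As far as these compounds go, whether chloro or methoxy could replace the methyl or fluoro group is equally open.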